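Chloro on the Acetamido Chain of a Benzimidazole Series

This account rests on a few compounds, and the source may have more. Where it says the series, first, only, none or still open, it means among the compounds named here.

Compound 1 `O=[N+]([O-])c1ccc(-c2nc3cc(C(F)(F)F)ccc3[nH]2)cc1` gives 6000 nM in an ADME assay on MDBK cells (Bos taurus) for cytotoxicity, read by MTT assay, with a stated time of 96 h; a lower number here means that less compound is tolerated, a higher number that more compound is tolerated.
Compound 2 `CCN(CC)CC(=O)Nc1ccc(-c2nc3cc(C(F)(F)F)ccc3[nH]2)cc1` gives 13000 nM in this assay.
Compound 3 `CC(=O)Nc1ccc(-c2nc3cc(C(F)(F)F)ccc3[nH]2)cc1` gives 50000 nM in this assay.

Compound 3 stands highest of the three numbers in this assay. Its nearest neighbour is compound 2, at a 3.8-fold higher number from compound 2 to compound 3 (0.59 log units; beyond the scatter), and the furthest is compound 1, at an 8.3-fold higher number from compound 1 to compound 3 (0.92 log units; beyond the scatter). The other measured step, a 2.2-fold higher number from compound 1 to compound 2 (0.34 log units; beyond the scatter), also lies beyond the scatter.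

Compound 4 `O=C(CCl)Nc1ccc(-c2nc3cc(C(F)(F)F)ccc3[nH]2)cc1` is not yet measured. It differs from compound 3 in one place: chloro in place of hydrogen on a saturated chain carbon bound to a carbonyl carbon. The step that bears most directly on this change is a 3.8-fold higher number from compound 2 to compound 3 (0.59 log units; beyond the scatter), which concerns the same saturated chain carbon bound to a carbonyl carbon: there, removing a substituent from that carbon raised the number. Placing a chloro group on that carbon is therefore expected to move the number in the opposite direction, by a modest step. The estimate for compound 4 is 15000 nM, within 4000 nM to 50000 nM, which corresponds to an expected step of a 3.3-fold lower number from compound 3 to compound 4 (0.52 log units; beyond the scatter).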

Compound 4, half-maximal cytotoxic concentration: 17000 nM
The estimate for compound 4 lay 1.1-fold (0.05 log units) below the measured number; the range from low to high includes it.
By their numbers in this assay, from the lowest: compound 1; then compounds 2 and 4 (each within the scatter of the next); then compound 3.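

In this assay, the saturated chain carbon bound to a carbonyl carbon responds to a single chloro atom, with a 2.9-fold lower number from compound 3 to compound 4 (0.47 log units; beyond the scatter). Earlier, only the much larger diethylamino group had been seen on that carbon, and chloro and diethylamino cannot be told apart there, at a 1.3-fold higher number from compound 2 to compound 4 (0.12 log units; within the scatter), so both leave the number lower than hydrogen does in compound 3. The chloro compound still keeps clear of the nitro compound, with a 2.8-fold higher number from compound 1 to compound 4 (0.45 log units; beyond the scatter).

Nothing at hand accounts for the effect of chloro at this carbon. From the compounds shown here alone, it remains open whether fluoro, a hydroxyl, a primary amine or a longer chain on that carbon would fall with chloro and diethylamino or stay with the hydrogen of compound 3.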